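The source may report more compounds than this note shows. Statements on the series, on what has been measured and on what is new or still open speak of the compounds shown alone.

Working notes on the series. Among the measured compounds shown here, compound 2 `O=C(/C=C/c1ccc(NC(=O)Nc2ccc(Cl)c(C(F)(F)F)c2)cc1)NC1CCC1` gives 17300 nM in a functional assay on KETR3 cells (Homo sapiens) for inhibition, read by MTT assay, with a stated time of 120 h (on this read-out lower numbers stand for stronger inhibition and higher numbers for weaker inhibition), the lowest of the three numbers measured so far. Compound 3 `CC(NC(=O)/C=C/c1ccc(NC(=O)Nc2ccc(Cl)c(C(F)(F)F)c2)cc1)c1ccccc1` gives 21200 nM in this assay; the step of a 1.2-fold higher number from compound 2 to compound 3 (0.09 log units; within the scatter) lies within the scatter, so these two compounds cannot be told apart. For the measured compounds named here, compound 1 `CC1CN(C(=O)c2ccc(-c3ccc(NC(=O)Nc4ccc(Cl)c(C(F)(F)F)c4)cc3)cc2)CC(C)O1` gives 41900 nM in this assay, a number beyond the scatter from compound 2; no single-point step links compound 1 to compound 2, so only the two values themselves can be compared.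

Compound 4 `CNC(=O)c1cccc(-c2ccc(NC(=O)Nc3ccc(Cl)c(C(F)(F)F)c3)cc2)c1` has not yet been measured. It differs from compound 2 by 3-(methylcarbamoyl)phenyl in place of 2-(cyclobutylcarbamoyl)ethenyl on an aromatic carbon. Going by the values given here, this change is of a different kind from the one measured step, which only swapped the group on the amide nitrogen. The nearest comparison is compound 1, which also carries an aromatic ring bearing an amide rather than the ethenyl amide, and which gives 41900 nM, a weaker result than compound 2. On that basis the step of a 1.7-fold higher number from compound 2 to compound 4 (0.24 log units; within the scatter) is expected to run toward a higher number, probably beyond the scatter but smaller than the gap to compound 1. Compound 4 is therefore estimated at 30000 nM in this assay, with a range from 12000 nM to 80000 nM.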

Compound 4, half-maximal inhibitory concentration: 39300 nM
Compound 4: middle estimate off by 1.3-fold (0.12 log units), on the low side; the measured number falls inside the stated range.
By their numbers in this assay, from the lowest: compounds 2, 3, 4 and 1 (each within the scatter of the next, the first and the last beyond it).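

At this position, on an aromatic carbon para to a large group, replacing the 2-(cyclobutylcarbamoyl)ethenyl group with 3-(methylcarbamoyl)phenyl gives a modest step in this assay that lies beyond the scatter (a 2.3-fold higher number from compound 2 to compound 4 (0.36 log units; beyond the scatter)), unlike the swap on the amide nitrogen (a 1.2-fold higher number from compound 2 to compound 3 (0.09 log units; within the scatter)). The two groups have the same counts of hydrogen-bond donors and acceptors and no net charge, so those counts do not separate them; the change instead replaces a four-membered non-aromatic carbon ring and an ethenyl link with a six-membered aromatic ring, and the cyclobutyl on the amide nitrogen with methyl. No evidence is available that explains this step.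

The single step changes the link and the amide nitrogen group together, so the compounds shown do not assign the higher number to either one; a 3-(cyclobutylcarbamoyl)phenyl group would separate the two. On these data alone, it also remains open how this position responds when the amide is replaced altogether, for example by a carboxylic acid or an amine.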